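Cyano in place of (trifluoromethyl)carbonyl on the shared core

A few compounds are considered here, and "the series" means these few. Any claim that something is new, unique, unknown or untested is made for them only; others in the source may bear on it.

Of the compounds shown here, three have been measured in an assay on isolated protein for displacement of a labelled ligand from Apoptosis regulator Bcl-2 (Homo sapiens), read by fluorescence polarization; a higher number here means a weaker inhibitor, a lower number a stronger inhibitor. Compound 1 `CN(C)CC[C@H](CSc1ccccc1)Nc1ccc(S(=O)(=O)NC(=O)c2ccc(N3CCN(Cc4ccccc4-c4ccc(Cl)cc4)CC3)cc2)cc1OC(F)(F)F` reaches only the limit of the assay, < 1 nM. Compound 2 `CN(C)CC[C@H](CSc1ccccc1)Nc1ccc(S(=O)(=O)NC(=O)c2ccc(N3CCN(Cc4ccccc4-c4ccc(Cl)cc4)CC3)cc2)cc1S(C)(=O)=O` likewise sits at a limit, < 1 nM. Compound 3 `CN(C)CC[C@H](CSc1ccccc1)Nc1ccc(S(=O)(=O)NC(=O)c2ccc(N3CCN(Cc4ccccc4-c4ccc(Cl)cc4)CC3)cc2)cc1C(=O)C(F)(F)F` also returns a limit rather than a number, < 1 nM. The steps among them are therefore not readable in size: a step that the two limits leave unreadable from compound 1 to compound 2, a step that the two limits leave unreadable from compound 1 to compound 3 and a step that the two limits leave unreadable from compound 2 to compound 3. All that can be said of compound 3 is that it stands at the limit of < 1 nM in this assay, at which 3 of the 3 values shown sit, together with the other two.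

Compound 4 `CN(C)CC[C@H](CSc1ccccc1)Nc1ccc(S(=O)(=O)NC(=O)c2ccc(N3CCN(Cc4ccccc4-c4ccc(Cl)cc4)CC3)cc2)cc1C#N` differs from compound 3 by cyano in place of (trifluoromethyl)carbonyl on an aromatic carbon. Among the compounds with values here, no measured step bears directly on this change; the only steps known all start and end at the limit and are unreadable. Since every variation of this group so far has stayed at the limit, compound 4 is expected to stay there too, with a step that the limit leaves unreadable from compound 3 to compound 4 not beyond the scatter. The estimate for compound 4 in this assay is 0.8 nM, within the range 0.2 nM to 3 nM.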

Compound 4, inhibition constant: < 1 nM
Compound 4 ended at the assay's limit; the forecaster's own chance of this, stated with the estimate: 65%; the middle value is on the limit's open side.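

No step involving compound 4 can be read, and the steps linking it to compound 1, compound 2 and compound 3 have no readable size: the limit of < 1 nM in this assay, at which 4 of the 4 values shown sit.

The compounds shown leave open whether cyano, (trifluoromethyl)carbonyl, methylsulfonyl and trifluoromethoxy differ at all in this assay.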